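Working notes: changing the carbonyl substituent of compound 3

A few compounds are considered here, and "the series" means these few. Any claim that something is new, unique, unknown or untested is made for them only; others in the source may bear on it.

Of the compounds shown here, three sharing one core have been read in a functional assay on L5178Y cells (Mus musculus) for inhibition, read by MTT assay, with a stated time of 24 h; on this read-out lower numbers stand for stronger inhibition and higher numbers for weaker inhibition. Compound 1 (`COc1cc(O)c2c(c1)O[C@H](c1ccc(O)cc1)C/C2=N\N`) gives >= 11300 nM, which is a limit of the assay and not a number. Among the compounds with values here, compound 2 (`COc1cc(O)c2c(c1)O[C@H](c1ccc(O)cc1)C/C2=N\Nc1ccc(Br)cn1`) gives 4300 nM, the only true number so far. Compound 3 (`COc1cc(O)c2c(c1)O[C@H](c1ccc(O)cc1)C/C2=N\NC(=O)Cc1c[nH]c2ccccc12`) gives >= 11300 nM, again a limit and not a number. On these data alone, compound 3 thus stands at the limit of >= 11300 nM in this assay, at which 2 of the 3 values shown sit, so how far its true value lies from that limit is unknown.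

Next in line is compound 4 (`COc1cc(O)c2c(c1)O[C@H](c1ccc(O)cc1)C/C2=N\NC(=O)OCc1ccccc1`), with benzyloxy in place of (1H-indol-3-yl)methyl on a carbonyl carbon.

Within the data shown here, the only measured step is an at least 2.6-fold lower number from compound 1 to compound 2 (0.41 log units; beyond the scatter), made with 5-bromopyridin-2-yl in place of hydrogen on an amine nitrogen. Among the measured compounds shown here, it bears on the change only loosely, as no measured step swaps one carbonyl substituent for another. No step beyond the scatter is therefore expected in this assay, although a modest move towards the value of compound 2 at 4300 nM stays possible. The estimated step is an at least 1.2-fold lower number from compound 3 to compound 4 (0.09 log units; that floor lies within the scatter). For compound 4 the estimated value is 9000 nM, with an expected range from 3500 nM to 20000 nM.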

Compound 4, half-maximal inhibitory concentration: >= 11300 nM
Compound 4: a limit, no number; the forecaster's own chance of this, stated with the estimate: 45%; at least 1.2-fold (0.09 log units) between middle value and limit.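

In this assay compound 4 gives >= 11300 nM and this is a limit of the assay, not a number. Benzyloxy on the carbonyl carbon therefore leaves the series where (1H-indol-3-yl)methyl left it: two quite different substituents on a carbonyl carbon bound to the amide-type nitrogen now both end at the limit, and the steps to compound 4 from compound 3 and from compound 1 cannot be read. Within the data shown here, the one readable new step is an at least 2.6-fold higher number from compound 2 to compound 4 (0.41 log units; beyond the scatter) with benzyloxycarbonyl in place of 5-bromopyridin-2-yl on an amine nitrogen, so the 5-bromopyridin-2-yl group remains the only substituent here with a true number, while the others give no ranking among themselves: the limit of >= 11300 nM in this assay, at which 3 of the 4 values shown sit.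

On these data alone, how far compound 1, compound 3 and compound 4 each lie from that limit remains unknown, so neither the indole nor the benzyl carbamate can be ranked against the free hydrazone. Also open, as far as these compounds go, is whether a carbonyl substituent of another kind, such as a 5-bromopyridin-2-yl group, a simple methyl, or a longer chain ending in an amine, would bring a true number in this assay.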